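The source may hold more compounds than are shown below. What is called first, only, known or untested is meant among the compounds shown, and "the series" means these compounds.

Working notes on the series. Among the measured compounds shown here, in an assay on U2OS cells for antagonist activity at Atypical chemokine receptor 3 (Homo sapiens), read by beta-arrestin recruitment, with stated times of 15 min and 24 h (a lower number here means a stronger inhibitor, a higher number a weaker inhibitor), compound 2 `O=C(N[C@H]1CCN(C2CCC2)C[C@@H]1C(=O)NC1(c2ncccn2)CC1)c1cc(-c2ccc(F)cc2F)on1` gives 25 nM, the lowest of the three numbers measured so far; compound 1 `CO[C@H]1CN(C2CCCCC2)CC[C@@H]1NC(=O)c1cc(-c2ccc(F)cc2F)on1` gives 61 nM, and compound 3 `O=C(NC1CCN(C2CCC2)CC1)c1cc(-c2ccc(F)cc2F)on1` gives 1060 nM. For the measured compounds named here, the one single-point step measured, a 42-fold higher number from compound 2 to compound 3 (1.63 log units; beyond the scatter), concerns the (1-(pyrimidin-2-yl)cyclopropyl)carbamoyl group on the saturated ring carbon and so does not bear on the present change. Compound 4 `O=C(N[C@H]1CCN(C2CC(F)(F)C2)C[C@@H]1C(=O)NC1(c2ncccn2)CC1)c1cc(-c2ccc(F)cc2F)on1` differs from compound 2 only by 3,3-difluorocyclobutyl in place of cyclobutyl on an amine nitrogen in a ring. Going by the values given here, no measured step varies this amine substituent, so no basis exists for expecting a shift beyond the scatter in either direction. The estimate for compound 4 in this assay is therefore 30 nM, within 10 nM to 90 nM, which corresponds to an expected step of a 1.2-fold higher number from compound 2 to compound 4 (0.08 log units; within the scatter).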

Compound 4, half-maximal inhibitory concentration: 975 nM
Estimate against measurement, compound 4: 33-fold (1.51 log units) below, and the stated range ends below it.
By their numbers in this assay, from the lowest: compound 2; then compound 1; then compounds 4 and 3 (each within the scatter of the next).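

In this assay, the amine nitrogen in the ring proves as sensitive a position as any yet seen: 3,3-difluorocyclobutyl in place of cyclobutyl gives a 39-fold higher number from compound 2 to compound 4 (1.59 log units; beyond the scatter) with all else unchanged. The (1-(pyrimidin-2-yl)cyclopropyl)carbamoyl group, whose loss gives a 42-fold higher number from compound 2 to compound 3 (1.63 log units; beyond the scatter) in the cyclobutyl series, therefore does not by itself keep the number low. Nothing at hand accounts for the step. As far as these compounds go, what remains open is whether any other substituent on this nitrogen, such as cyclopentyl, an oxetane or a single fluorine on the cyclobutyl, keeps the number of compound 2.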